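Removing the nitrile from the benzyl group of compound 3

The compounds below may be only part of what the source reports. "The series", "measured", "known", "first", "only" and "open" are said of these compounds alone.

Measured so far:
compound 1 `N#Cc1cccc(Cn2c(=O)n(C3OC(CO)[C@@H](O)[C@H]3O)c3nc(N)nc(O)c32)c1`: 16%
compound 2 `CCn1c(=O)n(C2OC(CO)[C@@H](O)[C@H]2O)c2nc(N)nc(O)c21`: 82%
compound 3 `N#Cc1ccc(Cn2c(=O)n(C3OC(CO)[C@@H](O)[C@H]3O)c3nc(N)nc(O)c32)cc1`: 50%

In a functional assay on the whole organism (B cells) with Mus musculus as the target (a higher number here means a larger maximal response, a lower number a smaller maximal response), compound 3 stands second of the three measured compounds, with compound 2 above it and compound 1 below it; both gaps lie beyond the scatter, a number 32 percentage points lower from compound 2 to compound 3 (beyond the scatter) and a number 34 percentage points higher from compound 1 to compound 3 (beyond the scatter). The next compound is compound 4 `Nc1nc(O)c2c(n1)n(C1OC(CO)[C@@H](O)[C@H]1O)c(=O)n2Cc1ccccc1`, which differs from compound 3 as follows: hydrogen in place of cyano on an aromatic carbon. Among the compounds with values here, no measured step is the same change. The steps that come nearest are the exchanges on the saturated chain carbon bound to the aromatic nitrogen: a number 66 percentage points higher from compound 1 to compound 2 (beyond the scatter) and a number 32 percentage points lower from compound 2 to compound 3 (beyond the scatter) show that a cyanophenyl in place of methyl lowers the maximal response, and a number 34 percentage points higher from compound 1 to compound 3 (beyond the scatter) shows that the position of the cyano on the ring matters greatly. The loss of the cyano in compound 4 is a smaller change than any of these. A step in this assay beyond the scatter is expected, upward, but of modest size, since compound 2 with 82% marks the highest value seen and compound 4 still carries the phenyl. For compound 4 the estimate is 62%, with a range of 38% to 86%. The expected step is a number 12 percentage points higher from compound 3 to compound 4 (beyond the scatter).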

Compound 4, largest response reached (reported as maximal response), in percent of the reference or control that the assay uses: 110%
Compound 4: middle estimate off by 48 percentage points, on the low side; the whole stated range lies below it.
By their numbers in this assay, from the lowest: compound 1; then compound 3; then compound 2; then compound 4.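

In this assay, the earlier compounds suggested that an aromatic ring on the chain carbon lowers the response relative to the small alkyl group, but the plain phenyl of compound 4 goes the other way, with a number 28 percentage points higher from compound 2 to compound 4 (beyond the scatter), so among these compounds the low values go with the nitrile-bearing rings and not with the ring itself. Taking the nitrile away accounts for a large rise from either cyano compound, with a number 60 percentage points higher from compound 3 to compound 4 (beyond the scatter) and a number 94 percentage points higher from compound 1 to compound 4 (beyond the scatter), and the position of the nitrile sets how much of the response is lost. Nothing available here gives a reason for these steps.

Still open, from the compounds shown here alone, is whether the nitrile in particular lowers the response or any group on that ring carbon would do so; a fluorine, a methoxy group or a carboxylic acid on the phenyl would separate these two readings. Also open, going by these compounds, is how the response changes between the ethyl of compound 2 and the benzyl of compound 4, and a longer chain such as propyl or phenethyl on the same nitrogen would test this.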